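A Furanyl Carbonyl Replaces the Phenylethenyl Carbonyl

The source may report more compounds than this note shows. Statements on the series, on what has been measured and on what is new or still open speak of the compounds shown alone.

Compound 1 `CN(c1cc2ncc(=O)[nH]c2cc1NC(=S)NC(=O)c1ccc(OC(F)(F)F)cc1)C1CCCCC1`, compound 2 `COc1cc(C(=O)NC(=S)Nc2cc3[nH]c(=O)cnc3cc2N(C)C2CCCCC2)cc(OC)c1OC` and compound 3 `CN(c1cc2ncc(=O)[nH]c2cc1NC(=S)NC(=O)/C=C/c1ccccc1)C1CCCCC1` share one core and differ only in the group on the carbonyl carbon. In an ADME assay on Huh-7 cells (Homo sapiens) for cytotoxicity (on this read-out lower numbers stand for stronger inhibition and higher numbers for weaker inhibition), compound 1 gives 6470 nM, compound 2 gives 15900 nM and compound 3 gives 11000 nM, the second highest of the three numbers. The step of a 2.5-fold higher number from compound 1 to compound 2 (0.39 log units; beyond the scatter) is modest, while a 1.7-fold higher number from compound 1 to compound 3 (0.23 log units; within the scatter) and a 1.4-fold lower number from compound 2 to compound 3 (0.16 log units; within the scatter) both lie within the scatter. Compound 4 `CN(c1cc2ncc(=O)[nH]c2cc1NC(=S)NC(=O)c1ccco1)C1CCCCC1` carries furan-2-yl in place of 2-phenylethenyl on a carbonyl carbon. Among the measured compounds shown here, none of the measured steps involves furan-2-yl, and the replacements made so far on that carbon moved this assay only slightly, so the step of a 1.1-fold lower number from compound 3 to compound 4 (0.04 log units; within the scatter) is expected to stay within the scatter, with no clear direction. Compound 4 is therefore estimated at 10000 nM in this assay, between 4000 nM and 25000 nM.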

Compound 4, half-maximal inhibitory concentration: 17300 nM
For compound 4 the middle estimate is 1.7-fold (0.24 log units) below the measured one, and the stated range covers the measured number.
By their numbers in this assay, from the lowest: compounds 1, 3, 2 and 4 (each within the scatter of the next, the first and the last beyond it).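

Furan-2-yl puts a five-membered aromatic ring with a hetero atom on this carbonyl carbon, yet a 1.6-fold higher number from compound 3 to compound 4 (0.20 log units; within the scatter) and a 1.1-fold higher number from compound 2 to compound 4 (0.04 log units; within the scatter) both stay within the scatter in this assay. Among the compounds shown here, the only new step beyond the scatter is a 2.7-fold higher number from compound 1 to compound 4 (0.43 log units; beyond the scatter) and it sets the 4-(trifluoromethoxy)phenyl group apart from furan-2-yl, although compound 3 remains within the scatter of compound 1. No available evidence accounts for these differences. From the compounds shown here alone, it remains open whether an aromatic ring is needed on this carbon at all. A longer alkyl chain, an amine or a carboxylic acid there might or might not move the number further.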